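A few compounds are considered here, and "the series" means these few. Any claim that something is new, unique, unknown or untested is made for them only; others in the source may bear on it.

Compound 1, `Cn1cnc2c(Sc3ccccc3)ncnc21`, was tested in an assay on isolated protein for inhibition of Ca2+/calmodulin-dependent protein kinase II (CaM kinase II) (Rattus norvegicus), tested at 30 uM (a lower number here means less inhibition, a higher number more inhibition at the concentration tested (going by the name of the read-out)), where compound 1 gives 8%. Two relatives differ from it in one place. Compound 2, `CSc1ccc(-c2nc3c(Sc4ccccc4)ncnc3n2C)cc1`, gives 0%, the step being a number 8 percentage points lower from compound 1 to compound 2 (within the scatter). Compound 3, `Cn1c(C#CCCO)nc2c(Sc3ccccc3)ncnc21`, gives 10%, with a number 2 percentage points higher from compound 1 to compound 3 (within the scatter). Between those two relatives the step is a number 10 percentage points higher from compound 2 to compound 3 (within the scatter). On the raw numbers compound 1 stands second highest of the three, yet every step among them lies within the scatter, so no ranking can be read from them.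

Compound 4, `Fc1ccc(Cn2cnc3c(Sc4ccccc4)ncnc32)cc1`, has not been measured. It differs from compound 1 by 4-fluorophenyl in place of hydrogen on a saturated chain carbon bound to an aromatic nitrogen. Going by the values given here, none of the measured steps touches this place: all three alter an aromatic carbon of the shared core, and all three stay within the scatter. They bear on compound 4 only indirectly, in that adding a larger group to the core at an aromatic carbon produced no shift beyond the scatter. Among the compounds with values here, no measured step speaks to substitution on the saturated chain carbon bound to an aromatic nitrogen. The expectation is therefore a step of no change at the digits printed from compound 1 to compound 4 (within the scatter) in this assay, which amounts to none beyond the scatter. Compound 4 is estimated at 8%, with a range from 0% to 22%.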

Compound 4, a percentage reported as inhibition, at one concentration (the size of the read-out at that concentration, not a potency): 0%
Beside the measured number, compound 4's estimate is 8 percentage points above it, and the stated range covers the measured number.
By their numbers in this assay, from the lowest: compounds 2, 4, 1 and 3 (each within the scatter of the next).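

In this assay, the only change shown at the saturated chain carbon bound to an aromatic nitrogen, methyl to 4-fluorobenzyl, gives a number 8 percentage points lower from compound 1 to compound 4 (within the scatter). Adding a 4-fluorophenyl group of 7 heavy atoms at this place therefore produces no shift beyond the scatter at the concentration tested. This position now stands with the aromatic carbon changed in compound 2 and compound 3 as a place where no change shown has moved the number beyond the scatter, and nothing in the data shown offers an explanation for this result.

Going by these compounds, whether an amine, a carboxylic acid or a longer chain in place of the 4-fluorobenzyl would move the number beyond the scatter remains open. Also open, on these data alone, is whether 4-fluorobenzyl at this place would give the same result with 4-hydroxybut-1-yn-1-yl or 4-(methylsulfanyl)phenyl on the aromatic carbon of the shared core.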